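The source may hold more compounds than are shown below. What is called first, only, known or untested is meant among the compounds shown, and "the series" means these compounds.

Measured compounds in a functional assay on HeLa cells (Homo sapiens) for cytotoxicity, read by CCK-8 assay, with a stated time of 72 h; on this read-out lower numbers stand for stronger inhibition and higher numbers for weaker inhibition:
compound 2 `C=CCn1c(=O)/c(=C\c2cccc(Br)c2)[nH]c(=O)/c1=C\c1ccccc1OC`, 5400 nM
compound 1 `C=CCn1c(=O)/c(=C\c2cccc(Cl)c2)[nH]c(=O)/c1=C\c1ccccc1OC`, 5500 nM

Compound 2 stands beside compound 1 at two numbers that lie within the scatter of each other, the step of a 1.0-fold lower number from compound 1 to compound 2 (0.01 log units; within the scatter) being too small to count. Compound 3 `C=CCn1c(=O)/c(=C\c2cccc(C)c2)[nH]c(=O)/c1=C\c1ccccc1OC` differs from compound 2 by methyl in place of bromo on an aromatic carbon. Among the compounds with values here, the only measured step, exchanging one halogen for another, gave no change beyond the scatter; no measured step tests a methyl in this place. With nothing in the data pointing either way, compound 3 is expected to stay close to compound 2, a step of a 1.0-fold higher number from compound 2 to compound 3 (0.01 log units; within the scatter) that is not beyond the scatter. Compound 3 is therefore estimated at 5500 nM, in the range 2500 nM to 12000 nM.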

Compound 3, half-maximal inhibitory concentration: 19300 nM
Estimate against measurement, compound 3: 3.5-fold (0.55 log units) below; the measured number lies above the stated range.
By their numbers in this assay, from the lowest: compounds 2 and 1 (each within the scatter of the next); then compound 3.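

In this assay, replacing a halogen with methyl at this place on the ring gives a 3.6-fold higher number from compound 2 to compound 3 (0.55 log units; beyond the scatter) and a 3.5-fold higher number from compound 1 to compound 3 (0.55 log units; beyond the scatter) while chloro and bromo remain within the scatter of each other. The position therefore responds to the group placed there, which the exchange of one halogen for another had not shown. Nothing available accounts for the difference between methyl and the halogens. The compounds shown leave open whether an amine, a nitrile or a methoxy group at this place would read like the halogens or like methyl.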